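Swapping Fluoro for Chloro on a Sulfonamide Cinnamamide

This account rests on a few compounds, and the source may have more. Where it says the series, first, only, none or still open, it means among the compounds named here.

Measured compounds:
Compound 1, `O=C(/C=C/c1ccc(Br)cc1)NS(=O)(=O)c1ccc(F)cc1`, gives 1.2 ug/mL in a functional assay on B16-F10 cells (Mus musculus) for antiproliferative activity, read by ELISA and MTT assay, with a stated time of 48 h; a lower number here means a stronger inhibitor, a higher number a weaker inhibitor.
Compound 2, `O=C(/C=C/c1ccc(Br)cc1)NS(=O)(=O)c1ccc(Cl)cc1`, gives 5.2 ug/mL in this assay.
Compound 3, `COc1ccc(/C=C/C(=O)NS(=O)(=O)c2ccc(F)cc2)cc1`, gives 5.1 ug/mL in this assay.

Compound 1 and compound 2 share one core and differ only by chloro in place of fluoro on an aromatic carbon; this change gave a 4.3-fold higher number from compound 1 to compound 2 (0.64 log units; beyond the scatter). Compound 3 carries a different core, which differs from that of compound 1 by methoxy in place of bromo on an aromatic carbon, a change that gave a 4.3-fold higher number from compound 1 to compound 3 (0.63 log units; beyond the scatter). The values of compound 2 and compound 3 lie within the scatter of each other, so no order between them can be read.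

Compound 4, `COc1ccc(/C=C/C(=O)NS(=O)(=O)c2ccc(Cl)cc2)cc1`, is not yet measured. It differs from compound 3 by chloro in place of fluoro on an aromatic carbon, the same change as that from compound 1 to compound 2, at the same place. If the change acts alike on the core of compound 3, compound 4 is expected to show a 3.5-fold higher number from compound 3 to compound 4 (0.55 log units; beyond the scatter) in this assay, because compound 1 to compound 2 gave a 4.3-fold higher number from compound 1 to compound 2 (0.64 log units; beyond the scatter). Among the compounds with values here, with only one earlier example of the change, the estimate is loose. Compound 4 is therefore estimated at 18 ug/mL, within 6 ug/mL to 55 ug/mL.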

Compound 4, half-maximal inhibitory concentration: 5.3 ug/mL
The estimate for compound 4 lay 3.4-fold (0.53 log units) above the measured number; measured number outside the range, below it.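

On the core of compound 3, chloro in place of fluoro gave a 1.0-fold higher number from compound 3 to compound 4 (0.02 log units; within the scatter), so the step seen on the core of compound 1 did not carry over to this second core: the same change on two cores in this assay, a 4.3-fold higher number (0.64 log units; beyond the scatter) from compound 1 to compound 2 and a 1.0-fold higher number (0.02 log units; within the scatter) from compound 3 to compound 4, 4.2-fold (0.62 log units) apart, beyond the scatter of two such steps

Methoxy in place of bromo likewise gave a 1.0-fold higher number from compound 2 to compound 4 (0.01 log units; within the scatter) once chloro was present, which does not match the step seen when fluoro was present: the same change on two cores in this assay, a 4.3-fold higher number (0.63 log units; beyond the scatter) from compound 1 to compound 3 and a 1.0-fold higher number (0.01 log units; within the scatter) from compound 2 to compound 4, 4.2-fold (0.62 log units) apart, beyond the scatter of two such steps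

In this assay, within the data shown here, these four compounds therefore show that neither change has a fixed size here, but both mismatches rest on the single value of compound 1, 1.2 ug/mL, and they do not show why the steps differ or how a further core would respond.

As far as these compounds go, it remains open whether the value of compound 1 is particular to bromo combined with fluoro, or would recur with iodo or trifluoromethyl in place of bromo. The compounds shown also leave open what a nitrile or an amine in place of fluoro or chloro would do on either core.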